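Sulfonylquinoline series: nitrile for chloromethylphenyl on the sulfonyl

The compounds below may be only part of what the source reports. "The series", "measured", "known", "first", "only" and "open" are said of these compounds alone.

Working notes on three measured compounds and one awaiting measurement. Compound 1 `CC1CCN(c2c(S(=O)(=O)c3cccc(C#N)c3)cnc3cc(Cl)ccc23)CC1`, compound 2 `Cc1ccc(S(=O)(=O)c2cnc3cc(Cl)ccc3c2N2CCC(C)CC2)cc1Cl` and compound 3 `Cc1ccc(S(=O)(=O)c2cnc3ccc(F)cc3c2N2CCC(C)CC2)cc1Cl` were run in an assay on isolated protein for displacement of a labelled ligand from metabotropic glutamate receptor 5 (Homo sapiens), with a stated time of 60 min, tested at 1 uM; a lower number here means less inhibition, a higher number more inhibition at the concentration tested (going by the name of the read-out). Compound 1 gives 94%. Compound 2 gives 89%, and compound 3 gives 91%. All three values lie within the scatter of one another, so no order among them is claimed.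

Compound 1 and compound 2 share a core and differ in one place, (3-cyanophenyl in place of 3-chloro-4-methylphenyl on a sulfonyl sulfur). That change gave a number 5 percentage points higher from compound 2 to compound 1 (within the scatter). Compound 3 carries a different core from compound 2; the difference between the two cores is not broken down here, and their values show only that both sit within the scatter of each other.

Compound 4 `CC1CCN(c2c(S(=O)(=O)c3cccc(C#N)c3)cnc3ccc(F)cc23)CC1` is not yet measured. Among the measured compounds shown here, it is related to compound 3 by 3-cyanophenyl in place of 3-chloro-4-methylphenyl on a sulfonyl sulfur, the same change in the same place as the one from compound 2 to compound 1, on a sulfonyl sulfur whose other neighbour is an aromatic carbon.

Because a number 5 percentage points higher from compound 2 to compound 1 (within the scatter) stayed within the scatter on the other core, the expected step is a number 2 percentage points higher from compound 3 to compound 4 (within the scatter). Since compound 3 already gives 91%, the room for a rise is small. For compound 4 the estimate in this assay is 93%, with a range from 85% to 99% that is expected to hold most repeats.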

Compound 4, a percentage reported as inhibition, at one concentration (the size of the read-out at that concentration, not a potency): 93%
Estimate against measurement, compound 4: no gap at the digits printed; the measured number falls inside the stated range.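

In this assay, 3-cyanophenyl in place of 3-chloro-4-methylphenyl on a sulfonyl sulfur gives a number 2 percentage points higher from compound 3 to compound 4 (within the scatter), and the change reads alike on the two cores: the same change on two cores in this assay, a number 5 percentage points higher (within the scatter) from compound 2 to compound 1 and a number 2 percentage points higher (within the scatter) from compound 3 to compound 4, 3 percentage points apart, within the scatter of two such steps. On these two cores, then, the exchange can be carried from one to the other without a step beyond the scatter, and the read-out registers no loss of inhibition with the nitrile-bearing group in place. It does not show that the change raises inhibition, since neither step exceeds the scatter, and as a reading at one concentration it gives no potency, so a difference within either pair could stay hidden with compound 3 already at 91%; two cores also give no rule for the wider series.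

The compounds shown leave open whether the same result holds for other groups on the sulfonyl sulfur, such as a phenyl ring carrying a carboxylic acid or a primary amine. From the compounds shown here alone, whether the two members of each pair separate at lower concentrations also remains open.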